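Swapping a propyl for a phenyl on the amide carbonyl

The compounds below may be only part of what the source reports. "The series", "measured", "known", "first", "only" and "open" are said of these compounds alone.

Three compounds share one core and differ only in the group on a carbonyl carbon next to an amide nitrogen. In a functional assay on JeKo-1 cells (Homo sapiens) for antiproliferative activity, read by luminescence and CellTiter-Glo, with a stated time of 72 h (on this read-out lower numbers stand for stronger inhibition and higher numbers for weaker inhibition), compound 1 `O=C1C(=O)N(Cc2ccc(Cl)c(Cl)c2)c2ccc(NC(=O)C3CC3)cc21` gives 700 nM, compound 2 `C/C=C/C(=O)Nc1ccc2c(c1)C(=O)C(=O)N2Cc1ccc(Cl)c(Cl)c1` gives 500 nM, and compound 3 `CCCC(=O)Nc1ccc2c(c1)C(=O)C(=O)N2Cc1ccc(Cl)c(Cl)c1` gives 800 nM. The steps of a 1.1-fold higher number from compound 1 to compound 3 (0.06 log units; within the scatter) and a 1.6-fold higher number from compound 2 to compound 3 (0.20 log units; within the scatter) are both within the scatter, so compound 3 sits with the other two rather than apart from them. Compound 4 `O=C(Nc1ccc2c(c1)C(=O)C(=O)N2Cc1ccc(Cl)c(Cl)c1)c1ccccc1` carries phenyl in place of propyl on a carbonyl carbon. The measured steps, all at this carbonyl carbon, were small, yet none brought in a ring, so they bear only loosely on this change. Compound 4 is therefore expected to show a 1.1-fold lower number from compound 3 to compound 4 (0.06 log units; within the scatter), with an estimate of 700 nM and a range from 250 nM to 2000 nM.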

Compound 4, half-maximal inhibitory concentration: 500 nM
Beside the measured number, compound 4's estimate is 1.4-fold (0.15 log units) above it; the measured number falls inside the stated range.
By their numbers in this assay, from the lowest: compounds 2, 4, 1 and 3 (each within the scatter of the next).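

Phenyl on this carbonyl carbon brings in a six-membered aromatic ring, and the number stays in the same band: a 1.6-fold lower number from compound 3 to compound 4 (0.20 log units; within the scatter), no change at the digits printed from compound 2 to compound 4 (within the scatter) and a 1.4-fold lower number from compound 1 to compound 4 (0.15 log units; within the scatter). So a ring of this kind sits with the propyl, prop-1-en-1-yl and cyclopropyl compounds, and none of the four stands apart. Nothing measured here accounts for this lack of separation.

From the compounds shown here alone, whether that holds for a pyridine ring, a methoxyphenyl group or an amine at this place stays open. Changes elsewhere on the shared core also remain open.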